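Replacing 4-methylphenyl with pyridin-2-yl against tumour cell growth

The compounds below may be only part of what the source reports. "The series", "measured", "known", "first", "only" and "open" are said of these compounds alone.

Within the data shown here, in a functional assay on IMR-32 cells (Homo sapiens) for antiproliferative activity, read by sulforhodamine B assay, with a stated time of 48 h (on this read-out higher numbers stand for weaker inhibition of growth and lower numbers for stronger inhibition of growth), compound 1 `Cc1ccc(-c2cn(CCCN3C(=O)COc4ccccc43)nn2)cc1` gives 4400 nM, the higher of the two numbers measured so far, so it is the weaker of the pair. Compound 2 `COc1ccc2cc(-c3cn(CCCN4C(=O)COc5ccccc54)nn3)ccc2c1` gives 1300 nM, a lower number by more than the usual scatter. Compound 3 `O=C1COc2ccccc2N1CCCn1cc(-c2ccccn2)nn1` has not yet been measured. It carries pyridin-2-yl in place of 4-methylphenyl on an aromatic carbon of the five-membered aromatic ring with 3 nitrogen (pyridin-2-yl in place of 4-methylphenyl on an aromatic carbon). Among the measured compounds shown here, no measured pair shows this exchange, so the expectation starts from compound 1 at 4400 nM and remains a judgement. A modest move toward weaker inhibition of growth is expected in this assay, with an estimated 2.3-fold higher number from compound 1 to compound 3 (0.36 log units; beyond the scatter). For compound 3 the estimated value is 10000 nM, with an expected range of 3500 nM to 30000 nM.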

Compound 3, concentration for 50% growth inhibition: 2000 nM
For compound 3 the middle estimate is 5.0-fold (0.70 log units) above the measured one; measured number outside the range, below it.
By their numbers in this assay, from the lowest: compounds 2 and 3 (each within the scatter of the next); then compound 1.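

In this assay, pyridin-2-yl on an aromatic carbon of a five-membered aromatic ring with 3 nitrogen gives stronger inhibition of growth than 4-methylphenyl (a 2.2-fold lower number from compound 1 to compound 3 (0.34 log units; beyond the scatter)), a modest step. Among these compounds, this is the first single exchange that can be read at this place, and it shows that a six-membered aromatic ring with 1 hetero atom and 1 hydrogen-bond acceptor is tolerated there. Compound 3 (2000 nM) lies within the scatter of compound 2 (1300 nM), so the smaller pyridin-2-yl matches the naphthalene-free reading only in number, and nothing measured here explains the step.

The compounds shown leave open whether the step follows the ring nitrogen or the loss of the methyl, a question that a plain phenyl group at this place would settle. They also leave open how pyridin-3-yl or pyridin-4-yl would read in this assay.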